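A few compounds are considered here, and "the series" means these few. Any claim that something is new, unique, unknown or untested is made for them only; others in the source may bear on it.

Of the compounds shown here, three sharing one core have been measured in an assay for inhibition of Indoleamine 2,3-dioxygenase 1 (Homo sapiens), with stated times of 10 min and 60 min, tested at 100 uM; a higher number here means a stronger effect of the compound at the concentration tested, a lower number a weaker effect. Compound 1, `O=C(O)c1cccc(CNc2cc(C(F)(F)F)cc3[nH]ncc23)c1`, gives 17%. Compound 2, `OC1CCCC(Nc2cccc(CNc3cc(C(F)(F)F)cc4[nH]ncc34)c2)C1`, gives 2%. Compound 3, `CNC(=O)c1cccc(CNc2cc(C(F)(F)F)cc3[nH]ncc23)c1`, gives 46% and thus stands highest of the three, with compound 1 nearest and compound 2 furthest, both steps to compound 3 lying beyond the scatter.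

Compound 4, `FC(F)(F)c1cc(NCc2cccc(Br)c2)c2cn[nH]c2c1`, has not yet been measured. It differs from compound 3 in one place: bromo in place of methylcarbamoyl on an aromatic carbon.

Among the compounds with values here, two measured steps touch this position of the ring. The change a number 29 percentage points higher from compound 1 to compound 3 (beyond the scatter) shows that altering the group at this place moved the number modestly, and the change a number 44 percentage points higher from compound 2 to compound 3 (beyond the scatter) shows a large movement once the methylcarbamoyl was present. Within the data shown here, no measured step replaces this group with a halogen, so the direction for compound 4 rests on the observation that the methylcarbamoyl of compound 3 accompanies the highest number. The expected step is a number 21 percentage points lower from compound 3 to compound 4 (beyond the scatter), a decrease. Compound 4 is therefore estimated at 25%, within a range from 5% to 50%.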

Compound 4, a percentage reported as inhibition, at one concentration (the size of the read-out at that concentration, not a potency): 51%
The estimate for compound 4 lay 26 percentage points below the measured number; measured number above the stated range.
By their numbers in this assay, from the lowest: compound 2; then compound 1; then compounds 3 and 4 (each within the scatter of the next).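

Replacing methylcarbamoyl with bromo gives a number 5 percentage points higher from compound 3 to compound 4 (within the scatter) and so shows that the amide is not required for the number seen at this place on the ring, since a single bromine atom with no hydrogen-bond donor or acceptor matches it. Bromo also clearly exceeds the two other groups tested here, with a number 34 percentage points higher from compound 1 to compound 4 (beyond the scatter) when it replaces carboxy and a number 49 percentage points higher from compound 2 to compound 4 (beyond the scatter) when it replaces (3-hydroxycyclohexyl)amino. Within the data shown here, the high number of compound 3 therefore cannot be treated as special to methylcarbamoyl, as the earlier compounds alone might have suggested.

On these data alone, it remains open whether chloro, a nitrile or a short alkyl chain would match bromo at this place. Nothing available accounts for the match between bromo and methylcarbamoyl.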